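Removing the Nitro Group From Compound 3

The compounds below may be only part of what the source reports. "The series", "measured", "known", "first", "only" and "open" are said of these compounds alone.

Compound 1 `Cc1nc2c3ccccc3ccc2c2nc3c(ccc4ccccc43)c(-c3ccccc3S)c12`: 89 ug/mL
Compound 2 `Cc1nc2c3ccccc3ccc2c2nc3c(ccc4ccccc43)c(-c3cc([N+](=O)[O-])ccc3N)c12`: 93.1 ug/mL
Compound 3 `Cc1nc2c3ccccc3ccc2c2nc3c(ccc4ccccc43)c(-c3cccc([N+](=O)[O-])c3)c12`: 117 ug/mL

In a functional assay, read by spectrophotometry, with a stated time of 30 min (on this read-out lower numbers stand for stronger inhibition and higher numbers for weaker inhibition), compound 3 stands within the scatter of the other two measured compounds: a 1.3-fold higher number from compound 1 to compound 3 (0.12 log units; within the scatter) and a 1.3-fold higher number from compound 2 to compound 3 (0.10 log units; within the scatter). Compound 4 `Cc1nc2c3ccccc3ccc2c2nc3c(ccc4ccccc43)c(-c3ccccc3)c12` differs from compound 3 by hydrogen in place of nitro on an aromatic carbon. Within the data shown here, no measured step removes a nitro group on its own. The nearest guides are a 1.0-fold higher number from compound 1 to compound 2 (0.02 log units; within the scatter), where the attached ring changed more extensively and the number hardly moved, and the two other steps, each also within the scatter. Across all three measured compounds the number barely changes, so no step beyond the scatter is expected in this assay. Compound 4 is therefore estimated at 105 ug/mL, with a range of 55 ug/mL to 200 ug/mL, meaning a 1.1-fold lower number from compound 3 to compound 4 (0.05 log units; within the scatter).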

Compound 4, half-maximal inhibitory concentration: 164 ug/mL
Compound 4: the middle estimate sits 1.6-fold (0.19 log units) below what was measured; measured number inside the range.
By their numbers in this assay, from the lowest: compounds 1, 2, 3 and 4 (each within the scatter of the next).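

In this assay, hydrogen in place of nitro gives a 1.4-fold higher number from compound 3 to compound 4 (0.15 log units; within the scatter) and so stays within the scatter. The plain phenyl ring also stays within the scatter of the other two attached rings, with a 1.8-fold higher number from compound 2 to compound 4 (0.25 log units; within the scatter) and a 1.8-fold higher number from compound 1 to compound 4 (0.27 log units; within the scatter) as the printed steps. In these four compounds, then, neither nitro, amino nor sulfanyl on this ring is needed to reach this level of inhibition. No measurement shown explains these small steps. On these data alone, whether a carboxylic acid or a longer chain on this ring would move the number beyond the scatter remains open.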